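The source may report more compounds than this note shows. Statements on the series, on what has been measured and on what is new or still open speak of the compounds shown alone.

In an ADME assay on MT4 cells (Homo sapiens) for cytotoxicity, read by MTT assay (on this read-out lower numbers stand for higher toxicity in this test and higher numbers for lower toxicity in this test), compound 3 `Cc1cc(C)cc(S(=O)(=O)c2c(C(=O)NC(c3ccc(Cl)cc3)C3CC3)[nH]c3ccc(Cl)cc23)c1` gives only a limit of the assay, > 47300 nM, not a number, so its place cannot be pinned down more closely than that; this is the point (the limit of > 47300 nM in this assay, at which 1 of the 3 values shown sits). Compound 4 `Cc1cc(C)cc(S(=O)(=O)c2c(C(=O)NCC(=O)NCc3ccncc3)[nH]c3ccc(Cl)cc23)c1` is not yet measured. It differs from compound 3 in one place: a group of 11 heavy atoms (8 carbon, 2 nitrogen, 1 oxygen; one six-membered aromatic ring with 1 hetero atom) in place of a group of 11 heavy atoms (10 carbon, 1 chlorine; one three-membered non-aromatic ring of carbon only, one six-membered aromatic ring of carbon only), on an amide-type nitrogen.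

Among the measured compounds shown here, no measured step changes exactly this part of the molecule. The nearest measured pair is compound 1 `Cc1cc(C)cc(S(=O)(=O)c2c(C(=O)NC(C)C(=O)NC(C)c3ccncc3)[nH]c3ccc(Cl)cc23)c1` and compound 2 `Cc1cc(C)cc(S(=O)(=O)c2c(C(=O)NC(C)C(=O)NCc3ccccc3F)[nH]c3ccc(Cl)cc23)c1`, which share with compound 4 the chain of two amide links on the shared core. In this assay compound 1 gives 21900 nM, and compound 2 gives 23300 nM; the step of a 1.1-fold higher number from compound 1 to compound 2 (0.03 log units; within the scatter) shows that swapping the group at the end of that chain leaves the read-out essentially unchanged. Compound 4 carries a chain of this kind, ending in a pyridin-4-yl methyl group, so its result is expected to resemble compounds 1 and 2 rather than the limit seen for compound 3. Compound 4 is therefore estimated at 25000 nM in this assay, with a range from 12000 nM to 50000 nM, which would mean an expected step of an at least 1.8-fold lower number from compound 3 to compound 4 (0.27 log units; that floor lies within the scatter).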

Compound 4, half-maximal cytotoxic concentration: > 48900 nM
Compound 4 ended at the assay's limit (the forecaster's own chance of this, stated with the estimate: 30%); middle value at least 1.9-fold (0.29 log units) from the limit.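

In this assay, compound 3 and compound 4 both end at a limit of the assay rather than at a number, so the step from compound 3 to compound 4 cannot be read. The compounds shown leave open how much placing (((pyridin-4-yl)methyl)carbamoyl)methyl on the amide-type nitrogen, in place of the group in compound 3, changes the read-out, or whether it changes it at all.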